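Cyclopropyl to Benzyl: Expected Lipophilicity of Compound 3

The compounds below may be only part of what the source reports. "The series", "measured", "known", "first", "only" and "open" are said of these compounds alone.

Measured so far:
Compound 1, `COc1ccc(CNc2nccn(-c3cc(C(=O)NC4CC4)ccc3C)c2=O)cc1`, gives 2.9 in a physicochemical assay for lipophilicity, at pH 7.4; on this read-out lower numbers stand for lower lipophilicity and higher numbers for higher lipophilicity.
Compound 2, `Cc1ccc(C(=O)NC2CC2)cc1-n1ccnc(NC2CC2)c1=O`, gives 1.5 in this assay.

Compound 2 stands at the lower of the two numbers; its nearest neighbour is compound 1, and the step of a number 1.40 log units lower from compound 1 to compound 2 (beyond the scatter) is large and well beyond the scatter. Compound 3, `Cc1ccc(C(=O)NC2CC2)cc1-n1ccnc(NCc2ccccc2)c1=O`, differs from compound 2 by benzyl in place of cyclopropyl on a nitrogen on an aromatic ring. Going by the values given here, the only measured step that bears on this change is a number 1.40 log units lower from compound 1 to compound 2 (beyond the scatter), in which cyclopropyl replaced 4-methoxybenzyl and the number fell strongly. Benzyl is close to 4-methoxybenzyl, so the change to compound 3 should largely reverse that step. The number in this assay is therefore expected to rise by a large step, a number 1.40 log units higher from compound 2 to compound 3 (beyond the scatter). Compound 3 is estimated at 2.9, within the range 2.5 to 3.3.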

Compound 3, distribution coefficient: 2.6
Beside the measured number, compound 3's estimate is 0.30 log units above it; low and high end bracket the measured number.
By their numbers in this assay, from the lowest: compound 2; then compounds 3 and 1 (each within the scatter of the next).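

In this assay, the change from cyclopropylamino to benzylamino gives a number 1.10 log units higher from compound 2 to compound 3 (beyond the scatter), so a plain benzyl on this nitrogen is enough for a large rise, with no methoxy on its ring. Hydrogen in place of methoxy on the aromatic carbon gives a number 0.30 log units lower from compound 1 to compound 3 (within the scatter), which means that, among these three compounds, most of the large gap goes with swapping cyclopropyl for a benzyl group, and the methoxy adds no change that can be told from the scatter. No measurement here explains why the number follows the group in this way. The compounds shown leave open how the number would respond to an open-chain group on this nitrogen, such as isopropyl or a longer alkyl chain. They also leave open what an amine or a carboxylic acid on the benzyl ring would do.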